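The source may hold more compounds than are shown below. What is called first, only, known or untested is meant among the compounds shown, and "the series" means these compounds.

Series notes, cytotoxicity on colon carcinoma cells.

Measured so far:
- compound 1 `COc1ccc(/C=C2\SC(=O)N(Cc3ccc(C(=O)O)cc3)C2=O)cc1`: 44000 nM
- compound 2 `O=C(O)c1ccc(CN2C(=O)S/C(=C\c3cccnc3)C2=O)cc1`: 90000 nM
- compound 3 `O=C(O)c1ccc(CN2C(=O)S/C(=C\c3ccccc3)C2=O)cc1`: 88000 nM

All three share one core and are tested in a functional assay on HT-29 cells (Homo sapiens) for cytotoxicity, read by MTT assay, with a stated time of 24 h; on this read-out lower numbers stand for stronger inhibition and higher numbers for weaker inhibition. Compound 1 gives the lowest of the three numbers, but its gap to compound 3, a 2.0-fold higher number from compound 1 to compound 3 (0.30 log units; within the scatter), sits within the scatter, while its gap to compound 2, a 2.0-fold higher number from compound 1 to compound 2 (0.31 log units; beyond the scatter), is only just beyond it. Compound 2 and compound 3 are indistinguishable, a 1.0-fold lower number from compound 2 to compound 3 (0.01 log units; within the scatter).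

Compound 4 `O=C(O)c1ccc(CN2C(=O)S/C(=C\c3ccc(Br)cc3)C2=O)cc1` is not yet measured. Against compound 1 the change is bromo in place of methoxy on an aromatic carbon. Among the measured compounds shown here, no measured step swaps one para substituent for another; the nearest comparison is the removal of the methoxy, a 2.0-fold higher number from compound 1 to compound 3 (0.30 log units; within the scatter), which stayed within scatter. Any change at this position has so far moved the number little, so compound 4 is expected near compound 1, perhaps somewhat weaker, as a step of a 1.4-fold higher number from compound 1 to compound 4 (0.13 log units; within the scatter). The estimate for compound 4 is 60000 nM, with a range of 25000 nM to 150000 nM.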

Compound 4, half-maximal inhibitory concentration: 30000 nM
Compound 4: middle estimate off by 2.0-fold (0.30 log units), on the high side; low and high end bracket the measured number.
By their numbers in this assay, from the lowest: compounds 4, 1, 3 and 2 (each within the scatter of the next, the first and the last beyond it).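

In this assay, the 4-bromophenyl group gives a step beyond the scatter against the unsubstituted phenyl (a 2.9-fold lower number from compound 3 to compound 4 (0.47 log units; beyond the scatter)), so a group on this aromatic carbon can shift the number, though only modestly; methoxy at the same carbon goes against any general rule, as its step from hydrogen stayed within the scatter. Bromo and methoxy cannot be ordered (a 1.5-fold lower number from compound 1 to compound 4 (0.17 log units; within the scatter)), even though only bromo separates clearly from hydrogen. The 4-bromophenyl group also separates from pyridin-3-yl (a 3.0-fold lower number from compound 2 to compound 4 (0.48 log units; beyond the scatter)), and that step is about the same size as the one from phenyl.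

No measurement on hand gives a reason for these steps. Still open, from the compounds shown here alone, is whether chloro, an amine or a nitrile on this carbon would follow bromo, or whether a longer chain there would move the number further.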